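Phenyl replacing propyl on the indole nitrogen substituent

The compounds below may be only part of what the source reports. "The series", "measured", "known", "first", "only" and "open" are said of these compounds alone.

In an assay on Prostate gland for inhibition of steroid 5-alpha-reductase (Rattus norvegicus) (a lower number here means a stronger inhibitor, a higher number a weaker inhibitor), compound 1 `CCCC(C)n1ccc2cc(/C(C)=C/C(=O)Nc3ccccc3OCCCC(=O)O)ccc21` gives 7.8 nM, the second highest of the three numbers and close to compound 2 `CCCC(C(C)C)n1ccc2cc(/C(C)=C/C(=O)Nc3ccccc3OCCCC(=O)O)ccc21` at 7.2 nM, with compound 3 `C/C(=C\C(=O)Nc1ccccc1OCCCC(=O)O)c1ccc2c(ccn2C(C)c2ccccc2)c1` at 19 nM furthest away. The step to compound 4 `C/C(=C\C(=O)Nc1ccccc1OCCCC(=O)O)c1ccc2c(ccn2C(CC(C)C)c2ccccc2)c1` is 3-methyl-1-phenylbutyl in place of 1-methylbutyl on an aromatic nitrogen. Going by the values given here, two measured steps bear on it: a 2.4-fold higher number from compound 1 to compound 3 (0.39 log units; beyond the scatter) and a 2.6-fold higher number from compound 2 to compound 3 (0.42 log units; beyond the scatter), both modest weakenings when a phenyl comes onto that carbon. By contrast a 1.1-fold lower number from compound 1 to compound 2 (0.03 log units; within the scatter), so chain size alone appears indifferent within these three compounds. A modest weakening is therefore expected, a 2.2-fold higher number from compound 1 to compound 4 (0.34 log units; beyond the scatter). Compound 4 is estimated at 17 nM in this assay, with a range of 8 nM to 40 nM.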

Compound 4, half-maximal inhibitory concentration: 6.3 nM
Beside the measured number, compound 4's estimate is 2.7-fold (0.43 log units) above it; the whole stated range lies above it.
By their numbers in this assay, from the lowest: compounds 4, 2 and 1 (each within the scatter of the next); then compound 3.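

The phenyl on the carbon bound to the aromatic nitrogen carries no penalty of its own in this assay when the substituent is 3-methyl-1-phenylbutyl (a 1.2-fold lower number from compound 1 to compound 4 (0.09 log units; within the scatter); a 1.1-fold lower number from compound 2 to compound 4 (0.06 log units; within the scatter)). The weakening seen with 1-phenylethyl does not hold for the larger group (a 3.0-fold lower number from compound 3 to compound 4 (0.48 log units; beyond the scatter)), so compound 3 stands apart from the other three compounds. No measured evidence accounts for this difference. Still open, on these data alone, is whether an amine or a fluorine on that phenyl keeps the number at this level, and whether a longer chain in place of the isopropyl end does the same.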